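A Second Methoxy Group on the Unmeasured Compound 3

The source may hold more compounds than are shown below. What is called first, only, known or untested is meant among the compounds shown, and "the series" means these compounds.

Measured compounds:
- compound 1 `COc1ccc(-c2cc(/C=C/C(=O)c3ccc(N)cc3)[nH]n2)cc1`: in a functional assay on SN12C cells (Homo sapiens) for cytotoxicity, read by sulforhodamine B assay, with a stated time of 48 h, tested at 0.01 uM (on this read-out higher numbers stand for a weaker effect at the one concentration tested and lower numbers for a stronger effect), compound 1 gives 93%
- compound 2 `COc1ccc(C(=O)/C=C/c2cc(-c3cc(OC)c(OC)c(OC)c3)n[nH]2)cc1OC`: in this assay compound 2 gives 99%

Of the two numbers shown, compound 1 supplies the numerically smaller one, yet compound 2 lies so close that the gap falls within the usual scatter, and the pair cannot be ranked. What the two values show together is that, at the single low concentration tested, neither compound produces more than a faint effect in this assay. Among the measured compounds shown here, no pair of compounds differing in a single place has been measured, so no step of known size is available to lean on.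

Compound 3 `COc1ccc(-c2cc(/C=C/C(=O)c3ccc(N)cc3)[nH]n2)cc1OC` differs from compound 1 by methoxy in place of hydrogen on an aromatic carbon. Given that compound 1 gives 93% and compound 2 gives 99% with a methoxy pattern already richer than that of compound 1, the step expected in this assay is a number 2 percentage points higher from compound 1 to compound 3 (within the scatter), which is to say none beyond the scatter. Compound 3 is therefore estimated at 95%, with a likely range from 85% to 105%.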

Compound 3, a percentage reported as activity, at one concentration (the size of the read-out at that concentration, not a potency): 101%
Beside the measured number, compound 3's estimate is 6 percentage points below it; the measured number falls inside the stated range.
By their numbers in this assay, from the lowest: compounds 1, 2 and 3 (each within the scatter of the next).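

Among the compounds shown here, compound 3 supplies the first step in this set between compounds that differ in one place. In this assay, methoxy in place of hydrogen on an aromatic carbon, at a place ortho to a methoxy group and meta to a large group, amounts to a number 8 percentage points higher from compound 1 to compound 3 (within the scatter). Earlier, compound 1 and compound 2 differed in more than one place and could say nothing about this position alone, whereas this step shows that, at the single low concentration tested, this one change does not separate compound 3 from compound 1 beyond the usual scatter, and nothing at hand bears on the reason for a step of this size.

Going by these compounds, since the read-out at this concentration shows only a faint effect for compound 1 and compound 3, it remains open whether the same change would stay within the scatter at a higher concentration, where a clearer effect might be seen. On these data alone, it also remains open whether a hydroxy group, a chlorine atom or a longer chain such as ethoxy at this same place would give a step beyond the scatter.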